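Adding pentyl to the chain of compound 2

The source may hold more compounds than are shown below. What is called first, only, known or untested is meant among the compounds shown, and "the series" means these compounds.

Compound 2 (`CCCCCCCO/N=C/c1cc(OC)c2c(c1OC)C(=O)C=CC2=O`) gives > 10 ug/mL in a functional assay on A549 cells (Homo sapiens) for antiproliferative activity (on this read-out higher numbers stand for an effect only at larger amounts of compound and lower numbers for an effect already at smaller amounts), which is a limit and not a number. Compound 3 (`CO/N=C/c1cc(OC)c2c(c1OC)C(=O)C=CC2=O`) gives > 10 ug/mL, also a limit. So compound 2 has no exact position, and the same is true across the series: the limit of > 10 ug/mL in this assay, at which 3 of the 3 values shown sit. Compound 4 (`CCCCCCCCCCCCO/N=C/c1cc(OC)c2c(c1OC)C(=O)C=CC2=O`) differs from compound 2 by pentyl in place of hydrogen on a saturated chain carbon, seven bonds along the chain from an oxygen on an unsaturated carbon. Compound 1 (`CCCCCCCCCCCCO/N=C(\CCCCCC)c1cc(OC)c2c(c1OC)C(=O)C=CC2=O`) carries that same longer chain and gives > 10 ug/mL, again a limit. Among the compounds with values here, the one measured step in this chain, a step that the two limits leave unreadable from compound 2 to compound 3, has no readable size. A clear change is therefore not expected, and the estimated step is a step that the limit leaves unreadable from compound 2 to compound 4. The expected value for compound 4 is 15 ug/mL, with an estimated range of 6 ug/mL to 40 ug/mL.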

Compound 4, concentration for half-maximal effect: > 10 ug/mL
Compound 4 ended at the assay's limit (the forecaster's own chance of this, stated with the estimate: 75%); the middle value does not contradict the limit.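

Compound 2 and compound 4 each give only a limit and not a number, so no step can be read between them. How much of any compound shown is needed for an effect in this assay stays open, because all of them share one result: the limit of > 10 ug/mL in this assay, at which 4 of the 4 values shown sit.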